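This account rests on a few compounds, and the source may have more. Where it says the series, first, only, none or still open, it means among the compounds named here.

Compound 2 `Cc1cc(NCCN(C)C)nc2ccc(NC(=O)c3ccc(Cl)c(Cl)c3)cc12`: 6670 nM
Compound 1 `CCN1CCN(c2cc(C)c3cc(NC(=O)c4ccccc4F)ccc3n2)CC1`: 38100 nM

Both numbers come from a functional assay on SK-BR-3 cells (Homo sapiens) for antiproliferative activity, read by MTT assay, with a stated time of 72 h; a higher number here means a weaker inhibitor, a lower number a stronger inhibitor. Of the two, compound 2 holds the lower one, and compound 1 sits at a higher number, a gap beyond the usual scatter of this assay.

Compound 3 `CCN(CC)CCNc1cc(C)c2cc(NC(=O)c3ccc(Cl)c(Cl)c3)ccc2n1` differs from compound 2 in one place: diethylamino in place of dimethylamino on a saturated chain carbon, two bonds along the chain from a nitrogen on an aromatic ring. Going by the values given here, no measured pair shows this change, so its size cannot be read from these two compounds. The step of a 1.2-fold lower number from compound 2 to compound 3 (0.08 log units; within the scatter) is expected to stay within the usual scatter. The estimate for compound 3 in this assay is 5500 nM, with a range from 2000 nM to 15000 nM.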

Compound 3, half-maximal inhibitory concentration: 3710 nM
Compound 3: middle estimate off by 1.5-fold (0.17 log units), on the high side, within the range that was stated.
By their numbers in this assay, from the lowest: compounds 3 and 2 (each within the scatter of the next); then compound 1.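

In this assay, putting diethylamino in place of dimethylamino on this chain gives a 1.8-fold lower number from compound 2 to compound 3 (0.25 log units; within the scatter) and so leaves the reading unchanged within the scatter. Going by these compounds alone, this is the first pair that isolates a change at this position, and it shows that the bigger of these two amines is accepted here without a clear gain or loss. Nothing measured here explains this result.

Still open, going by these compounds, is how a ring amine such as piperidine or morpholine would read in place of diethylamino. A longer chain carrying the same diethylamino group is also untested by these compounds.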